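Exchanging Bromo for Methyl: An Expectation for Compound 4

The compounds below may be only part of what the source reports. "The series", "measured", "known", "first", "only" and "open" are said of these compounds alone.

The measured compounds, each with its value in a functional assay on B16-F10 cells (Mus musculus) for antiproliferative activity, read by MTT assay, with a stated time of 48 h; a lower number here means a stronger inhibitor, a higher number a weaker inhibitor:
compound 1, `COc1ccc(/C=C/C(=O)Nc2cc(-c3ccc(Br)cc3)[nH]n2)cc1`, gives 770 nM
compound 2, `O=C(/C=C/c1ccc(Br)cc1)Nc1cc(-c2ccccc2)[nH]n1`, gives 1380 nM
compound 3, `COc1ccc(/C=C/C(=O)Nc2cc(-c3ccc(C)cc3)[nH]n2)cc1`, gives 1370 nM

Compound 1 and compound 2 share the core of this set, but how their cores differ is not broken down here. Compound 1 and compound 3 differ in a single place: methyl in place of bromo on an aromatic carbon. This step is a 1.8-fold higher number from compound 1 to compound 3 (0.25 log units; within the scatter). Compound 2 lies close to both of them, and the gaps between compound 2, compound 3 and compound 1 all fall within the scatter, so no order among the three is claimed.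

Compound 4, `Cc1ccc(/C=C/C(=O)Nc2cc(-c3ccccc3)[nH]n2)cc1`, has not yet been measured. It differs from compound 2 as methyl in place of bromo on an aromatic carbon. The place of this change is the same, word for word, as in the pair of compound 1 and compound 3, so it is the same change, occurring in two pairs of the set.

For compound 4 in this assay the expected step is a 1.6-fold higher number from compound 2 to compound 4 (0.20 log units; within the scatter), because the step of a 1.8-fold higher number from compound 1 to compound 3 (0.25 log units; within the scatter) gives the only measured case of the same change. Compound 4 is therefore estimated at 2200 nM, with a range from 900 nM to 5500 nM.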

Compound 4, half-maximal inhibitory concentration: 1680 nM
Compound 4: middle estimate off by 1.3-fold (0.12 log units), on the high side; the measured number falls inside the stated range.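

In this assay, exchanging bromo for methyl on the core of compound 2 gives a 1.2-fold higher number from compound 2 to compound 4 (0.09 log units; within the scatter). Set beside the earlier case, the two steps cannot be told apart: the same change on two cores in this assay, a 1.8-fold higher number (0.25 log units; within the scatter) from compound 1 to compound 3 and a 1.2-fold higher number (0.09 log units; within the scatter) from compound 2 to compound 4, 1.5-fold (0.16 log units) apart, within the scatter of two such steps. This shows that, on these two cores, the change from 4-bromophenyl to 4-methylphenyl gives steps that agree within the scatter, but each step also lies within the scatter on its own, so the data do not show that the change moves the number at all, and two pairs do not establish that the agreement would hold on a third core.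

The compounds shown leave open how the number in this assay would read with a group of a different kind in the same place, such as an amine, a carboxylic acid or a longer chain. They also leave open whether a step beyond the scatter can be reached at this position on either core.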